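The source may report more compounds than this note shows. Statements on the series, on what has been measured and on what is new or still open speak of the compounds shown alone.

Compound 1 `COc1cc(OC)c2c(=O)cc(/C=C/c3ccc(Cl)cc3)oc2c1` belongs to a small set of compounds sharing one core, studied in a functional assay on A549 cells (Homo sapiens) for antiproliferative activity, read by MTT assay, with a stated time of 12 h; on this read-out lower numbers stand for stronger inhibition and higher numbers for weaker inhibition. In this assay compound 1 reached only the limit of the measurement, giving > 40000 nM. Compound 2 `COc1ccc2c(=O)cc(/C=C/c3ccc(OC(F)(F)F)cc3)oc2c1` likewise gave only a limit, > 40000 nM. Compound 3 `COc1cc(/C=C/c2cc(=O)c3c(OC)cc(OC)cc3o2)cc(OC)c1` gave a number, 15600 nM. Compound 1 thus stands at the limit of > 40000 nM in this assay, at which 2 of the 3 values shown sit, and no number is known for it. Compound 4 `COc1cc(OC)c2c(=O)cc(/C=C/c3ccc(C(F)(F)F)cc3)oc2c1` has not yet been measured; it differs from compound 1 by trifluoromethyl in place of chloro on an aromatic carbon. Within the data shown here, no step between two measured compounds is known here. The step expected for this change, a number no higher from compound 1 to compound 4 (the limit leaves the size open), is expected to lie within the scatter, none beyond it. Compound 4 is therefore estimated at 40000 nM, within a range from 15000 nM to 100000 nM, and most likely only a limit would again be reported.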

Compound 4, half-maximal inhibitory concentration: > 40000 nM
Compound 4 ended at the assay's limit (the forecaster's own chance of this, stated with the estimate: 75%); the middle value lies on the limit itself.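

Compound 1 and compound 4 both gave only a limit, not a number, so the step between them cannot be read. The compounds shown leave open whether trifluoromethyl in place of chloro changes activity at all.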